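Carboxyphenyl variation at the ether end of the series

A few compounds are considered here, and "the series" means these few. Any claim that something is new, unique, unknown or untested is made for them only; others in the source may bear on it.

Measured compounds:
compound 1 `Cc1c(OCCCCOc2ccc(C(=O)O)cc2F)ccc(C(=O)CC(C)C)c1O`, 102 nM
compound 2 `Cc1ccc(C(=O)O)cc1OCCCCOc1ccc(C(=O)CC(C)C)c(O)c1C`, 454 nM
compound 3 `Cc1ccc(C(=O)O)cc1OCCCCOc1ccc(C(=O)CC2CCCC2)c(O)c1C`, 1290 nM

In an assay on HEK293 cells for positive allosteric modulation of metabotropic glutamate receptor 2 (Rattus norvegicus), read by thallium flux, with a stated time of 2.5 min (a higher number here means that more compound is needed for the effect, a lower number that less compound is needed), compound 2 sits second highest of the three numbers: compound 3 is nearest, a 2.8-fold higher number from compound 2 to compound 3 (0.45 log units; beyond the scatter), and compound 1 is furthest, a 4.5-fold higher number from compound 1 to compound 2 (0.65 log units; beyond the scatter). Compound 4 `Cc1c(OCCCCOc2ccccc2C(=O)O)ccc(C(=O)CC(C)C)c1O` is not yet measured; it differs from compound 2 by 2-carboxyphenyl in place of 5-carboxy-2-methylphenyl on an oxygen on a saturated carbon. Among the compounds with values here, the only measured step at the carboxyphenyl end is a 4.5-fold higher number from compound 1 to compound 2 (0.65 log units; beyond the scatter), a modest shift beyond the scatter. Within the data shown here, no measured pair contains a 2-carboxyphenyl group, so the direction is open; a step of similar modest size is expected, here a 1.4-fold higher number from compound 2 to compound 4 (0.16 log units; within the scatter). For compound 4 the estimate in this assay is 650 nM, with a range of 150 nM to 2800 nM.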

Compound 4, half-maximal effective concentration: 415 nM
The estimate for compound 4 lay 1.6-fold (0.19 log units) above the measured number; the range from low to high includes it.
By their numbers in this assay, from the lowest: compound 1; then compounds 4 and 2 (each within the scatter of the next); then compound 3.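

In this assay, 2-carboxyphenyl in place of 5-carboxy-2-methylphenyl gives a 1.1-fold lower number from compound 2 to compound 4 (0.04 log units; within the scatter), so these two groups cannot be told apart at this position, and the methyl group of compound 2 shows no separate contribution. Against 4-carboxy-2-fluorophenyl, the same group gives a 4.1-fold higher number from compound 1 to compound 4 (0.61 log units; beyond the scatter), leaving compound 1 alone among the three carboxyphenyl variants, with compounds 2 and 4 both beyond the scatter from it. No available data bear on the cause of these steps.

Still open, going by these compounds, is whether the fluorine or the carboxyl placement sets compound 1 apart, a question that plain 4-carboxyphenyl would address. Also open, on these data alone, is how a tetrazole in place of the carboxylic acid would read at this position.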